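The compounds below may be only part of what the source reports. "The series", "measured", "known", "first", "only" and "open" are said of these compounds alone.

Working notes on the series

Compound 1 `COc1ccc(CS(=O)(=O)/C=C/c2c(OC)cccc2OC)cc1[N+](=O)[O-]` is the parent of this set. In a functional assay on K562 cells (Homo sapiens) for cytotoxicity, read by trypan blue exclusion, with a stated time of 96 h (on this read-out higher numbers stand for weaker inhibition and lower numbers for stronger inhibition), compound 1 gives 20000 nM. Compound 2 `COc1ccc(CS(=O)(=O)/C=C/c2c(OC)cccc2OC)cc1N` carries an amino group where compound 1 carries a nitro group; the counted difference is amino in place of nitro on an aromatic carbon, and in this assay compound 2 gives 50 nM. The step is a 400-fold lower number from compound 1 to compound 2 (2.60 log units; beyond the scatter).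

Compound 3 `COc1ccc(CS(=O)(=O)/C=C/c2c(OC)cc(O)cc2OC)cc1[N+](=O)[O-]` differs from compound 1 in its core, the counted difference being (hydroxy in place of hydrogen on an aromatic carbon). In this assay compound 3 gives 5000 nM, a step of a 4.0-fold lower number from compound 1 to compound 3 (0.60 log units; beyond the scatter). Between compound 3 and compound 2 no single change is tallied; their two numbers simply stand as given above.

Compound 4 `COc1ccc(CS(=O)(=O)/C=C/c2c(OC)cc(O)cc2OC)cc1N` is not yet measured. It relates to compound 3 as compound 2 relates to compound 1: the counted difference is amino in place of nitro on an aromatic carbon, and the place description reads the same in both cases, so this is the same change seen once already among the measured compounds.

For the measured compounds named here, for compound 4 in this assay a step of about a 330-fold lower number from compound 3 to compound 4 (2.52 log units; beyond the scatter) is expected, resting on the single earlier instance of this change, a 400-fold lower number from compound 1 to compound 2 (2.60 log units; beyond the scatter), applied to the number of compound 3, 5000 nM. Going by the values given here, with only one prior example the size is uncertain and is taken somewhat smaller than that earlier step. Compound 4 is estimated at 15 nM, with a range from 4 nM to 60 nM.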

Compound 4, half-maximal inhibitory concentration: 300 nM
Compound 4: the middle estimate sits 20-fold (1.30 log units) below what was measured, and the stated range ends below it.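

In this assay, amino in place of nitro on an aromatic carbon gives a lower number on both cores, but with the hydroxy group present the step shrinks to a 17-fold lower number from compound 3 to compound 4 (1.22 log units; beyond the scatter), and the two instances do not match in size: the same change on two cores in this assay, a 400-fold lower number (2.60 log units; beyond the scatter) from compound 1 to compound 2 and a 17-fold lower number (1.22 log units; beyond the scatter) from compound 3 to compound 4, 24-fold (1.38 log units) apart, beyond the scatter of two such steps Hydroxy in place of hydrogen on an aromatic carbon does not even keep its direction, since it lowers the number on the nitro core but gives a 6.0-fold higher number from compound 2 to compound 4 (0.78 log units; beyond the scatter) on the amino core: the same change on two cores in this assay, a 4.0-fold lower number (0.60 log units; beyond the scatter) from compound 1 to compound 3 and a 6.0-fold higher number (0.78 log units; beyond the scatter) from compound 2 to compound 4, 24-fold (1.38 log units) apart, beyond the scatter of two such steps So the direction of the amino-for-nitro step carries from one core to the other, while its size does not, and neither size nor direction of the hydroxy step carries; since both comparisons rest on the same four compounds, they show that the two changes do not add up independently here, but not what lies behind this or whether it holds on any other core.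

The compounds shown leave open whether an acetamide or a dimethylamino group in place of the amino group would keep the low number of compound 2. Also open, from the compounds shown here alone, is whether a fluorine or a methoxy group in place of the hydroxy group would behave as the hydroxy group does on either core.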